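The source may report more compounds than this note shows. Statements on the series, on what has been measured and on what is new or still open speak of the compounds shown alone.

Measured so far in a functional assay on CHO-K1 cells for antagonist activity at melanin-concentrating hormone receptor 1 (Homo sapiens), read by inositol phosphate accumulation, with stated times of 10 min and 45 min; on this read-out lower numbers stand for stronger inhibition and higher numbers for weaker inhibition:
compound 1 `COCCC1(O)CCN(c2nc(C)c3cc(NC(=O)/C=C/c4ccc(Cl)cc4)ccc3n2)CC1`, 220 nM
compound 2 `Cc1nc(N2CCC(N3CCCS3(=O)=O)CC2)nc2ccc(NC(=O)/C=C/c3ccc(OC(F)(F)F)cc3)cc12`, 16 nM

Compound 2 stands at the lowest of the two numbers; compound 1 sits at a higher number, and that gap lies beyond the scatter. Compound 3 `Cc1nc(N2CCC(N3CCNC3=O)CC2)nc2ccc(NC(=O)/C=C/c3ccc(OC(F)(F)F)cc3)cc12` is not yet measured and differs from compound 2 in one place: a group of 6 heavy atoms (3 carbon, 2 nitrogen, 1 oxygen; one five-membered non-aromatic ring with 2 hetero atoms) in place of a group of 7 heavy atoms (3 carbon, 1 nitrogen, 2 oxygen, 1 sulfur; one five-membered non-aromatic ring with 2 hetero atoms), on a saturated ring carbon. Going by the values given here, no measured pair shows this change, so its size is open; a step within the scatter, with no clear direction, is expected in this assay, namely a 1.6-fold higher number from compound 2 to compound 3 (0.19 log units; within the scatter). Compound 3 is estimated at 25 nM in this assay, with a range from 8 nM to 80 nM.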

Compound 3, half-maximal inhibitory concentration: 31 nM
Beside the measured number, compound 3's estimate is 1.2-fold (0.09 log units) below it; the range from low to high includes it.
By their numbers in this assay, from the lowest: compounds 2 and 3 (each within the scatter of the next); then compound 1.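

In this assay, 2-oxoimidazolidin-1-yl on the saturated ring carbon in place of the sulfur-containing ring gives a 1.9-fold higher number from compound 2 to compound 3 (0.29 log units; within the scatter), so this position accepts both five-membered rings without a change beyond the scatter. The pair also shows that the sulfur-containing group can give way to a group carrying a hydrogen-bond donor with the number staying within the scatter. Nothing available accounts for this result. Still open, as far as these compounds go, is how a primary amine, a carboxylic acid or an open-chain urea would fare on this carbon. Also open, from the compounds shown here alone, is whether a six-membered cyclic urea would stay within the scatter of these two five-membered rings.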